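Aryl Swap on a Fused Bicyclic Core at the Receptor

The compounds below may be only part of what the source reports. "The series", "measured", "known", "first", "only" and "open" are said of these compounds alone.

In an assay on HEK-293T cells for displacement of a labelled ligand from corticotropin-releasing factor receptor 1 (Homo sapiens), read by scintillation counting, with a stated time of 2 h (a higher number here means a weaker inhibitor, a lower number a stronger inhibitor), compound 2 `CCCCN(CC)c1cc(C)nc2c1NC(=O)CN2c1ccc(OC)cc1C` gives 4 nM, the higher of the two numbers recorded so far. Its nearest neighbour is compound 1 `CCCCN(CC)c1cc(C)nc2c1NC(=O)CN2c1ccc(Br)cc1Cl`, which gives 2.7 nM in this assay. Among the compounds with values here, the only measured step is a 1.5-fold higher number from compound 1 to compound 2 (0.17 log units; within the scatter), and it stays within the scatter. Compound 3 `CCCCN(CC)c1cc(C)nc2c1NC(=O)CN2c1ccc(Br)cc1CC` has not yet been measured. It differs from compound 2 as follows: 4-bromo-2-ethylphenyl in place of 4-methoxy-2-methylphenyl on a nitrogen on an aromatic ring in a ring. Within the data shown here, the one step that bears on this change is the small one already seen between compound 1 and compound 2, and compound 3 brings back the bromine that compound 1 carries. Accordingly no step beyond the scatter is expected in this assay, and the expected step is a 1.3-fold lower number from compound 2 to compound 3 (0.12 log units; within the scatter). Compound 3 is therefore estimated to give 3 nM in this assay, with a range from 1 nM to 10 nM.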

Compound 3, inhibition constant: 2.5 nM
Compound 3: the middle estimate sits 1.2-fold (0.08 log units) above what was measured; the measured number falls inside the stated range.
By their numbers in this assay, from the lowest: compounds 3, 1 and 2 (each within the scatter of the next).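

In this assay, ethyl in place of chloro on an aromatic carbon, with the bromine kept, gives a 1.1-fold lower number from compound 1 to compound 3 (0.03 log units; within the scatter), which isolates a single substituent on the aryl group where the earlier step changed two at once. The swap of 4-methoxy-2-methylphenyl for 4-bromo-2-ethylphenyl gives a 1.6-fold lower number from compound 2 to compound 3 (0.20 log units; within the scatter), so the hydrogen-bond acceptor counted in the leaving group can be lost with no step beyond the scatter, and all three aryl groups on this nitrogen read alike. Nothing at hand explains this sameness.

The compounds shown leave open whether this position would read the same with a longer chain such as propyl in place of the ethyl, or with an amine or a carboxylic acid on the phenyl ring. They also leave open how far the butyl and ethyl chains on the shared core can change.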